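The source may hold more compounds than are shown below. What is called first, only, known or untested is meant among the compounds shown, and "the series" means these compounds.

In a functional assay on MCF7 cells (Homo sapiens) for inhibition, read by MTT assay, with a stated time of 72 h (on this read-out higher numbers stand for weaker inhibition of growth and lower numbers for stronger inhibition of growth), compound 1 `CC1(C)CCC[C@]2(C)[C@@H](C=O)C(C=O)=CC[C@@H]12` gives 75000 nM, while compound 2 `COC(=O)/C=C/C1=CC[C@H]2C(C)(C)CCC[C@]2(C)[C@H]1C=O` gives 7000 nM, the lower of the two numbers. Compound 3 `CCOC(=O)/C=C/C1=CC[C@H]2C(C)(C)CCC[C@]2(C)[C@H]1C=O` differs from compound 2 by one small change: methyl in place of hydrogen on a saturated chain carbon bound to an oxygen next to a carbonyl group, which turns methoxycarbonyl to ethoxycarbonyl. Within the data shown here, the only measured step, an 11-fold lower number from compound 1 to compound 2 (1.03 log units; beyond the scatter), is large, but it replaces a whole group and so offers little guide to a change this small. No shift beyond the scatter is therefore expected, in either direction, and the expected step is no change at the digits printed from compound 2 to compound 3 (within the scatter). For compound 3 the estimated value is 7000 nM, with a range of 3000 nM to 16000 nM.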

Compound 3, concentration for 50% growth inhibition: 30000 nM
The estimate for compound 3 lay 4.3-fold (0.63 log units) below the measured number; measured number above the stated range.
By their numbers in this assay, from the lowest: compound 2; then compound 3; then compound 1.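

The step of a 4.3-fold higher number from compound 2 to compound 3 (0.63 log units; beyond the scatter) in this assay shows that growth inhibition responds even to one added methyl, and that ethoxycarbonyl is weaker here than methoxycarbonyl. The 2-(ethoxycarbonyl)ethenyl group still keeps an edge over formyl, with a 2.5-fold lower number from compound 1 to compound 3 (0.40 log units; beyond the scatter) as the step, but that edge is smaller than the one the methoxycarbonyl version held. Nothing measured here gives a reason for these shifts. On these data alone, whether a longer chain such as propoxycarbonyl would raise the number further remains open, as does how a carboxylic acid would compare.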